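Trifluoromethyl for Methyl on an Oxime Ether Benzyl Ring

A few compounds are considered here, and "the series" means these few. Any claim that something is new, unique, unknown or untested is made for them only; others in the source may bear on it.

Measured compounds:
- compound 1, `Cc1nn(-c2ccccc2)c(Oc2ccc(Cl)cc2)c1/C=N/OCc1ccc(C(=O)OC(C)(C)C)cc1`, -9.9%
- compound 2, `Cc1ccc(CO/N=C/c2c(C)nn(C)c2Oc2ccc(Cl)cc2)cc1`, 30.4%

Both were tested in a functional assay on MKN-45 cells (Homo sapiens) for antiproliferative activity, tested at 1 uM; a higher number here means more inhibition at the concentration tested (going by the name of the read-out), a lower number less inhibition. Compound 2 holds the higher of the two values, and its gap to compound 1 lies beyond the scatter, so the two do differ. Compound 1 and compound 2 differ in more than one place, so no single change can be credited for that gap.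

Compound 3, `Cc1nn(C)c(Oc2ccc(Cl)cc2)c1/C=N/OCc1ccc(C(F)(F)F)cc1`, has not yet been measured. It keeps the core of compound 2 and changes one group on the outer six-membered aromatic ring of carbon only:

trifluoromethyl in place of methyl on an aromatic carbon

Among the measured compounds shown here, no measured pair here shows what this exchange alone does, so the direction of a number 1.6 percentage points higher from compound 2 to compound 3 (within the scatter) is expected to be small, within the scatter, with no firm lean either way. Compound 3 is therefore expected to give about 32%, with a wide range from 5% to 60%.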

Compound 3, a percentage reported as inhibition, at one concentration (the size of the read-out at that concentration, not a potency): 27.6%
Compound 3: middle estimate off by 4.4 percentage points, on the high side, and the stated range covers the measured number.
By their numbers in this assay, from the lowest: compound 1; then compounds 3 and 2 (each within the scatter of the next).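

In this assay, among the compounds shown here, trifluoromethyl in place of methyl gives a number 2.8 percentage points lower from compound 2 to compound 3 (within the scatter), the first exchange that can be read on its own, and it does not tell the two compounds apart. At this place on the six-membered aromatic ring, para to a large group, a group of four heavy atoms and a group of one heavy atom therefore read alike at the concentration tested. No measurement on hand explains why they read alike.

Methyl and trifluoromethyl both count no hydrogen-bond donors or acceptors, so it remains open how an amine or a carboxylic acid at this place would read. As far as these compounds go, it also remains open whether this same exchange would read alike on a different core, or at another concentration.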